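Working notes: from 4-methylbenzyl to 2-cyanobenzyl

The compounds below may be only part of what the source reports. "The series", "measured", "known", "first", "only" and "open" are said of these compounds alone.

- compound 1 `N#Cc1cccc(Cn2cc(CNC3=C(Cl)C(=O)c4cccnc4C3=O)nn2)c1` gives 4900 nM
- compound 2 `Cc1ccc(Cn2cc(CNC3=C(Cl)C(=O)c4cccnc4C3=O)nn2)cc1` gives 4630 nM

In a functional assay on MDA-MB-231 cells (Homo sapiens) for antiproliferative activity, read by sulforhodamine B assay, with a stated time of 72 h (a higher number here means a weaker inhibitor, a lower number a stronger inhibitor), compound 2 stands within the scatter of compound 1. Compound 3 `N#Cc1ccccc1Cn1cc(CNC2=C(Cl)C(=O)c3cccnc3C2=O)nn1` brings the change 2-cyanophenyl in place of 4-methylphenyl on a saturated chain carbon bound to an aromatic nitrogen and so puts 2-cyanophenyl in place of 4-methylphenyl on a saturated chain carbon bound to an aromatic nitrogen. For the measured compounds named here, the one measured step at this place is a 1.1-fold lower number from compound 1 to compound 2 (0.02 log units; within the scatter) and no measured compound carries 2-cyanophenyl. No step beyond the scatter, in either direction, is therefore expected in this assay. The estimated move is a 1.0-fold lower number from compound 2 to compound 3 (0.01 log units; within the scatter) and stays within the scatter. Compound 3 is expected at 4500 nM (estimated range 2000 nM to 10000 nM).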

Compound 3, half-maximal inhibitory concentration: 4860 nM
Compound 3: middle estimate off by 1.1-fold (0.03 log units), on the low side, within the range that was stated.
By their numbers in this assay, from the lowest: compounds 2, 3 and 1 (each within the scatter of the next).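

In this assay 2-cyanophenyl on a saturated chain carbon bound to an aromatic nitrogen stays within the scatter of 4-methylphenyl (a 1.0-fold higher number from compound 2 to compound 3 (0.02 log units; within the scatter)) and of 3-cyanophenyl (a 1.0-fold lower number from compound 1 to compound 3 (0.00 log units; within the scatter)). Across compounds 1, 2 and 3, neither the swap of nitrile for methyl nor the shift from 3-cyanophenyl to 2-cyanophenyl separates the numbers at this place. No measurement available here accounts for this flat reading. On these data alone, whether an amine or a carboxylic acid on the aromatic ring, or a longer chain in place of the single saturated carbon, would give a step beyond the scatter remains open.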